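Pyridinyl in Place of Methoxyphenyl on the Pyrazole Nitrogen

The compounds below may be only part of what the source reports. "The series", "measured", "known", "first", "only" and "open" are said of these compounds alone.

Measured so far:
compound 1, `COc1ccccc1-n1nc(C2CC(C)(C)OC(C)(C)C2)cc1-c1ccc(Cl)cc1`, 1 nM
compound 2, `COc1ccccc1-n1nc(C2CCOC(C)(C)C2)cc1-c1ccc(Cl)cc1`, 2 nM
compound 3, `COc1ccccc1-n1nc(C2CC(C)(C)OC(C)(C)C2)cc1-c1csc(Cl)c1`, 6 nM

In an assay on HEK293 cells for inhibition of Voltage-dependent N-type calcium channel subunit alpha-1B (Homo sapiens), read by fluorescence and calcium flux, with a stated time of 5 min (a lower number here means a stronger inhibitor, a higher number a weaker inhibitor), compound 1 gives the lowest of the three numbers. Compound 2 comes nearest, with a 2.0-fold higher number from compound 1 to compound 2 (0.30 log units; within the scatter); compound 3 sits furthest, with a 6.0-fold higher number from compound 1 to compound 3 (0.78 log units; beyond the scatter). Compound 4, `CC1(C)CC(c2cc(-c3ccc(Cl)cc3)n(-c3ccccn3)n2)CC(C)(C)O1`, differs from compound 1 in one place: pyridin-2-yl in place of 2-methoxyphenyl on an aromatic nitrogen. Among the measured compounds shown here, neither measured step touches this position; the step from compound 1 to compound 2 alters the oxane and the step from compound 1 to compound 3 alters the chlorophenyl, so no measured step bears directly on the change. Given that compound 1 already holds the lowest number, a modest rise is expected for compound 4, a 4.0-fold higher number from compound 1 to compound 4 (0.60 log units; beyond the scatter), and its value is estimated at 4 nM, between 1 nM and 15 nM.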

Compound 4, half-maximal inhibitory concentration: 12 nM
Compound 4: middle estimate off by 3.0-fold (0.48 log units), on the low side; low and high end bracket the measured number.
By their numbers in this assay, from the lowest: compounds 1 and 2 (each within the scatter of the next); then compounds 3 and 4 (each within the scatter of the next).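

In this assay, among the compounds shown here, the change on the aromatic nitrogen gives a 12-fold higher number from compound 1 to compound 4 (1.08 log units; beyond the scatter), so this position, untouched by the earlier steps, does respond to the group it carries. Pyridin-2-yl is a clearly poorer replacement for 2-methoxyphenyl in the setting of compound 1. Nothing available explains the rise.

The step removes the methoxy group and brings in a ring nitrogen at once, and the compounds shown do not separate the two. Going by these compounds, a plain phenyl group at this position would be the direct comparison, and whether the rise carries over to the other compounds remains open.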